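Dibromocatechol series: from formyl to ethoxymethyl

The source may report more compounds than this note shows. Statements on the series, on what has been measured and on what is new or still open speak of the compounds shown alone.

Working notes on a set of dibrominated dihydroxybenzenes tested in a functional assay on HCT-116 cells (Homo sapiens) for cytotoxicity, read by MTT assay, with a stated time of 96 h; a higher number here means a weaker inhibitor, a lower number a stronger inhibitor. Compound 1 `O=Cc1cc(Br)c(O)c(O)c1Br` carries a formyl group on the shared core; in this assay compound 1 is recorded as "not determined" (no result reported), so no single number is available for it. Compound 2 `CCCOCc1cc(O)c(O)c(Br)c1Br`, bearing a propoxymethyl group, gives 1320 nM in this assay. Compound 3 `OCc1cc(O)c(O)c(Br)c1Br`, the free hydroxymethyl analogue, gives 20400 nM in this assay. Among the compounds with values here, the only step within the measured pair is a 15-fold higher number from compound 2 to compound 3 (1.19 log units; beyond the scatter), so removing the alkyl from the ether oxygen was accompanied by a clearly weaker result.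

Compound 4 `CCOCc1cc(Br)c(O)c(O)c1Br` is the next member; it differs from compound 1 by ethoxymethyl in place of formyl on an aromatic carbon. Within the data shown here, no measured step speaks to the formyl group directly. The change does place an alkoxymethyl group on the core, as in compound 2, and the step from compound 2 to compound 3 suggests that an alkyl ether at this site sits on the stronger side of the series, though the bromo and hydroxy pattern of compound 4 differs from that of compound 2 and compound 3. On that basis compound 4 is expected to give about 2500 nM in this assay, within roughly 600 nM to 10000 nM.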

Compound 4, half-maximal inhibitory concentration: 1540 nM
For compound 4 the middle estimate is 1.6-fold (0.21 log units) above the measured one; the range from low to high includes it.
By their numbers in this assay, from the lowest: compounds 2 and 4 (each within the scatter of the next); then compound 3.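

No new step can be read for compound 4: compound 1 has no single number in this assay to compare with it, and compound 2 and compound 3 differ from it in more than one place. No measured evidence bears on this result. The compounds shown leave open how formyl and ethoxymethyl compare on the shared core, and what the bromo and hydroxy pattern contributes on its own.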